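Silyl ether size and cytotoxicity on KB cells

A few compounds are considered here, and "the series" means these few. Any claim that something is new, unique, unknown or untested is made for them only; others in the source may bear on it.

Measured so far:
compound 1 `C=C1CC[C@@H]2[C@](C)(CO[Si](C)(C)C(C)(C)C)[C@H](O)CC[C@@]2(C)[C@@H]1C/C=C1/C(=O)OC[C@H]1O`, 40.7 uM
compound 2 `C=C1CC[C@@H]2[C@](C)(CO[Si](C(C)C)(C(C)C)C(C)C)[C@H](O)CC[C@@]2(C)[C@@H]1C/C=C1/C(=O)OC[C@H]1O`, 2.73 uM

In a functional assay on KB cells (Homo sapiens) for cytotoxicity, read by sulforhodamine B assay (on this read-out lower numbers stand for an effect already at smaller amounts and higher numbers for an effect only at larger amounts of compound), compound 2 gives the lowest of the two numbers; compound 1 sits at a 15-fold lower number from compound 1 to compound 2 (1.17 log units; beyond the scatter) away from it. Among the measured compounds shown here, compound 3 `C=C1CC[C@@H]2[C@](C)(COC(C)=O)[C@H](O)CC[C@@]2(C)[C@@H]1C/C=C1/C(=O)OC[C@H]1O` differs from compound 2 by a group of 3 heavy atoms (2 carbon, 1 oxygen; no ring) in place of a group of 10 heavy atoms (9 carbon, 1 silicon; no ring), on an oxygen on a saturated carbon, so the group on that oxygen becomes much smaller, whereas the only measured step went the other way: enlarging the group from compound 1 to compound 2 gave a 15-fold lower number from compound 1 to compound 2 (1.17 log units; beyond the scatter). If size at this position matters in the same way, the move to the small acetyl in compound 3 should raise the number, possibly past compound 1, though no measured pair contains an acetyl. Compound 3 is therefore estimated at 30 uM, between 8 uM and 100 uM, a step of an 11-fold higher number from compound 2 to compound 3 (1.04 log units; beyond the scatter) expected in this assay.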

Compound 3, concentration for half-maximal effect: 15.3 uM
Estimate against measurement, compound 3: 2.0-fold (0.29 log units) above; the range from low to high includes it.
By their numbers in this assay, from the lowest: compound 2; then compound 3; then compound 1.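

In this assay, going to the acetyl gives a 5.6-fold higher number from compound 2 to compound 3 (0.75 log units; beyond the scatter) and also a 2.7-fold lower number from compound 1 to compound 3 (0.42 log units; beyond the scatter), so the number does not follow the count of heavy atoms on this oxygen. The group with the fewest heavy atoms lands in the middle, and compound 1, with the mid-sized group, has the highest number of the three, against any steady trend with size. A group without silicon can also give a lower number than one of the silyl groups, yet nothing measured here explains this order.

Going by these compounds, what remains open is whether the order reflects size at all, or something else that differs between a silyl group and an acetyl. A longer chain ester such as hexanoyl, a benzoyl group or a bare hydroxyl on this oxygen would each add a further point for comparison.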